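Ester to Acid on a Soluble Side Chain

The source may hold more compounds than are shown below. What is called first, only, known or untested is meant among the compounds shown, and "the series" means these compounds.

Measured so far in a physicochemical assay for solubility, in phosphate buffer, at pH 6.5; on this read-out higher numbers stand for higher solubility and lower numbers for lower solubility:
- compound 1 `C=C[C@@H]1C[C@]1(NC(=O)[C@@H]1C[C@@H](Oc2nccc3cc(OC)ccc23)CN1C(=O)[C@@H](NC(=O)NC(C)(C)C)C(C)(C)C)C(=O)NS(=O)(=O)C1CC1` gives 13 ug/mL
- compound 2 `C=C[C@@H]1C[C@]1(NC(=O)[C@@H]1C[C@@H](Oc2nccc3cc(OC)ccc23)CN1C(=O)[C@@H](NC(=O)N[C@@H](C)COC)C(C)(C)C)C(=O)NS(=O)(=O)C1CC1` gives 1070 ug/mL
- compound 3 `C=C[C@@H]1C[C@]1(NC(=O)[C@@H]1C[C@@H](Oc2nccc3cc(OC)ccc23)CN1C(=O)[C@@H](NC(=O)N[C@H](C(=O)OC)C(C)(C)C)C(C)(C)C)C(=O)NS(=O)(=O)C1CC1` gives 754 ug/mL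

Compound 3 at 754 ug/mL belongs to the upper pair of these values. Its distance from the lowest value is a 58-fold higher number from compound 1 to compound 3 (1.76 log units; beyond the scatter) and its distance within the pair is a 1.4-fold lower number from compound 2 to compound 3 (0.15 log units; within the scatter) so the upper two cannot be told apart.

Compound 4 `C=C[C@@H]1C[C@]1(NC(=O)[C@@H]1C[C@@H](Oc2nccc3cc(OC)ccc23)CN1C(=O)[C@@H](NC(=O)N[C@H](C(=O)O)C(C)(C)C)C(C)(C)C)C(=O)NS(=O)(=O)C1CC1` carries one change: hydrogen in place of methyl on an oxygen next to a carbonyl group and so methoxycarbonyl becomes carboxy. Within the data shown here, no measured pair shows this exchange itself. The nearest evidence lies on the same side chain, where an 82-fold higher number from compound 1 to compound 2 (1.92 log units; beyond the scatter) and a 58-fold higher number from compound 1 to compound 3 (1.76 log units; beyond the scatter) are both large and both upward. Both of those steps, however, replace tert-butyl, which is a different change. Between the two replacements, the step of a 1.4-fold lower number from compound 2 to compound 3 (0.15 log units; within the scatter) stays within the scatter. The large steps therefore do not carry over directly, and only a moderate rise in this assay is expected, perhaps one no larger than the scatter. The expected step is a 2.4-fold higher number from compound 3 to compound 4 (0.38 log units; beyond the scatter) as an estimate only. For compound 4 the estimated value is 1800 ug/mL with 600 ug/mL to 5000 ug/mL as the expected range.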

Compound 4, solubility: > 1160 ug/mL
Compound 4 ended at the assay's limit; the forecaster's own chance of this, stated with the estimate: 10%; the middle value lies beyond the limit too.
By their numbers in this assay, from the lowest: compound 1; then compounds 3 and 2 (each within the scatter of the next). At a limit, above all of these: compound 4.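

In this assay, the reading of compound 4 is a limit and not a number: the limit of > 1160 ug/mL in this assay, at which 1 of the 4 values shown sits. The earlier compounds shown here showed two replacements of tert-butyl on the amide-type nitrogen that gave large steps, and the 1-carboxy-2,2-dimethylpropyl group now makes a third, with an at least 89-fold higher number from compound 1 to compound 4 (1.95 log units; beyond the scatter). Exchanging methyl for hydrogen on the oxygen turns methoxycarbonyl into carboxy and keeps this position at the high end of the series, but the size of that exchange stays unresolved: an at least 1.5-fold higher number from compound 3 to compound 4 (0.18 log units; that floor lies within the scatter) and an at least 1.0-fold higher number from compound 2 to compound 4 (0.03 log units; that floor lies within the scatter) are both floors that lie within the scatter, and neither shows a real gain or rules one out.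

On these data alone, how far compound 4 lies beyond its limit remains open, and with it the true distance between compound 4 and the two compounds with the methoxycarbonyl and methoxy side chains. Also open, as far as these compounds go, is whether an amine in place of the carboxy group, or a longer chain carrying the carboxy group, would stay in this high range.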